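A few compounds are considered here, and "the series" means these few. Any claim that something is new, unique, unknown or untested is made for them only; others in the source may bear on it.

Three compounds share one core and differ only in the aryl group on the aromatic nitrogen of the five-membered aromatic ring with three nitrogens. Compound 1 `C/C(=C\CC/C(C)=C/CC[C@@H]1[C@@]2(C)CCC(=O)C(C)(C)[C@H]2CC[C@@]1(C)O)CC/C=C(\C)C(=O)OCc1cn(-c2ccc(C(F)(F)F)cc2)nn1` carries trifluoromethyl on an aromatic carbon; in an ADME assay on L132 cells (Homo sapiens) for cytotoxicity, read by MTT assay, with a stated time of 48 h (a lower number here means a stronger inhibitor, a higher number a weaker inhibitor), compound 1 gives > 150000 nM, which is a limit of the assay and not a number. Compound 2 `C/C(=C\CC/C(C)=C/CC[C@@H]1[C@@]2(C)CCC(=O)C(C)(C)[C@H]2CC[C@@]1(C)O)CC/C=C(\C)C(=O)OCc1cn(-c2ccc(Br)cc2)nn1` carries bromo instead; compound 2 gives > 150000 nM, likewise a limit. Within the data shown here, compound 3 `C/C(=C\CC/C(C)=C/CC[C@@H]1[C@@]2(C)CCC(=O)C(C)(C)[C@H]2CC[C@@]1(C)O)CC/C=C(\C)C(=O)OCc1cn(-c2ccc(C(C)(C)C)cc2)nn1` carries tert-butyl and gives 65800 nM, the only real number among the three. The measured steps were an at least 2.2-fold lower number from compound 1 to compound 3 (0.35 log units; beyond the scatter) and an at least 2.2-fold lower number from compound 2 to compound 3 (0.35 log units; beyond the scatter), while between the two limits lies a step that the two limits leave unreadable from compound 1 to compound 2. Compound 4 `C/C(=C\CC/C(C)=C/CC[C@@H]1[C@@]2(C)CCC(=O)C(C)(C)[C@H]2CC[C@@]1(C)O)CC/C=C(\C)C(=O)OCc1cn(-c2ccccc2F)nn1` introduces (2-fluorophenyl in place of 4-(tert-butyl)phenyl on an aromatic nitrogen). Because two of the three values sit at the limit of > 150000 nM in this assay, at which 2 of the 3 values shown sit, compound 4 is expected to return toward that limit, an estimated step of a 2.3-fold higher number from compound 3 to compound 4 (0.36 log units; beyond the scatter). Compound 4 is therefore estimated at 150000 nM, between 60000 nM and 300000 nM.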

Compound 4, half-maximal inhibitory concentration: > 150000 nM
Compound 4 gave a limit, no number; the forecaster's own chance of this, stated with the estimate: 65%; the middle value lies on the limit itself.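

Among these compounds, with an at least 2.2-fold higher number from compound 3 to compound 4 (0.35 log units; beyond the scatter), the single measurable value in this assay remains tied to the 4-(tert-butyl)phenyl group, and a third aryl group on this aromatic nitrogen fails to keep it. Compound 4 sits at a limit, which is not a number: the limit of > 150000 nM in this assay, at which 3 of the 4 values shown sit. The steps from compound 1 and compound 2 to compound 4 cannot be read, since both ends are limits.

As far as these compounds go, it remains open whether a smaller isopropyl group or a longer butyl chain in place of tert-butyl would also give a number, and what an amine on the aryl ring would do.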